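The source may report more compounds than this note shows. Statements on the series, on what has been measured and on what is new or still open speak of the compounds shown alone.

Compound 1 `CC(C(=O)NCc1ccc(C(F)(F)F)cc1N1CCCCCCC1)c1ccc(NS(C)(=O)=O)c(F)c1` gives 2.8 nM in an assay on CHO cells for antagonist activity at transient receptor potential cation channel subfamily V member 1 (Homo sapiens), read by FLIPR; on this read-out lower numbers stand for stronger inhibition and higher numbers for weaker inhibition.
Compound 2 `CC(C(=O)NCc1ccc(C(F)(F)F)cc1-c1ccc(C(C)(C)C)cc1)c1ccc(NS(C)(=O)=O)c(F)c1` gives 1.1 nM in this assay.

Among the measured compounds shown here, compound 2 therefore holds the lowest of the two numbers measured so far, and its only neighbour is compound 1, reached by a 2.5-fold lower number from compound 1 to compound 2 (0.41 log units; beyond the scatter). For the measured compounds named here, that single step exchanges an eight-membered non-aromatic ring with one nitrogen for a six-membered aromatic carbon ring on the same aromatic carbon of the shared core, and it is the only measured step available.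

Compound 3 `COc1cc(OC)cc(-c2cc(C(F)(F)F)ccc2CNC(=O)C(C)c2ccc(NS(C)(=O)=O)c(F)c2)c1` is the next compound, and it differs from compound 2 by 3,5-dimethoxyphenyl in place of 4-(tert-butyl)phenyl on an aromatic carbon. Going by the values given here, no measured step exchanges one aromatic ring for another at this place, so the step from compound 1 to compound 2 bears on it only loosely: it shows that an aromatic carbon ring at this place is compatible with a low number, but says nothing about replacing a tert-butyl group with two methoxy groups. In this assay a step for compound 3 of about a 2.0-fold higher number from compound 2 to compound 3 (0.30 log units; within the scatter) is expected, most likely within the scatter or a small rise. The estimate for compound 3 is 2.2 nM, with a range from 0.6 nM to 8 nM.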

Compound 3, inhibition constant: 5.8 nM
Estimate against measurement, compound 3: 2.6-fold (0.42 log units) below; the range from low to high includes it.
By their numbers in this assay, from the lowest: compound 2; then compound 1; then compound 3.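

Exchanging 4-(tert-butyl)phenyl for 3,5-dimethoxyphenyl keeps the six-membered aromatic ring of carbon only and the same count of heavy atoms, yet in this assay it gives a 5.3-fold higher number from compound 2 to compound 3 (0.72 log units; beyond the scatter) and so shows that this position responds to what the aromatic ring carries, not merely to the ring being there. The aromatic ring alone also does not guarantee a lower number than the eight-membered ring with one nitrogen, since the change to the 3,5-dimethoxyphenyl group gives a 2.1-fold higher number from compound 1 to compound 3 (0.32 log units; beyond the scatter) and so runs opposite to the earlier step to the 4-(tert-butyl)phenyl group. No measurement at hand explains why these two aromatic groups differ.

The compounds shown leave open whether the difference follows from the kind of group on the aromatic ring or from where it sits, which a 4-methoxyphenyl or a 3,5-di(tert-butyl)phenyl group could help separate. Also open, on these data alone, is how a pyridine ring, a piperidine ring or a morpholine ring would compare at this position.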